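The source may report more compounds than this note shows. Statements on the series, on what has been measured and on what is new or still open speak of the compounds shown alone.

In an ADME assay on HEL cells (Homo sapiens) for cytotoxicity, with a stated time of 3 days (on this read-out lower numbers stand for higher toxicity in this test and higher numbers for lower toxicity in this test), the three measured compounds give these values:

Compound 1 `O=S1(=O)C=C(OCc2ccccc2)C(Cc2ccccc2)(Cc2ccccc2)O1` gives 200000 nM.
Compound 2 `CCC1(Cc2ccccc2)OS(=O)(=O)C=C1OCc1ccc(OC)cc1` gives only a limit of the assay, > 200000 nM.
Compound 3 `CCC1(CC)OS(=O)(=O)C=C1OCc1ccccc1` gives 200000 nM.

The read-out is a concentration, so a larger number means that more compound is needed before the cells are harmed. All three compounds sit at the top end of what was tested. Compound 2 stands at the limit of > 200000 nM in this assay, at which 1 of the 3 values shown sits, which means that no harm was seen up to the highest concentration tried and the true value is not known, only that it lies beyond this point. Compound 1 and compound 3 give numbers at that same point rather than a limit.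

Compound 4 `CCC1(Cc2ccccc2)OS(=O)(=O)C=C1OC` is the next compound to be measured in this assay. Compared with compound 2, the change is hydrogen in place of 4-methoxyphenyl on a saturated chain carbon bound to an oxygen on an unsaturated carbon.

Going by the values given here, no step between two measured compounds is recorded, so there is nothing to show how such a change moves the read-out. Since compound 1, compound 2 and compound 3 all sit at the same ceiling despite different groups on the shared core, the expectation is a step no larger than the usual scatter, with no direction, so that a number no higher from compound 2 to compound 4 (the limit leaves the size open) is estimated to be flat. Compound 4 is therefore expected to give about 200000 nM, with a range from 100000 nM to 400000 nM, and most likely the assay again reports only a limit.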

Compound 4, half-maximal cytotoxic concentration: > 200000 nM
Compound 4: only a limit was reported (the forecaster's own chance of this, stated with the estimate: 65%); the middle value lies on the limit itself.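

No step can be read from compound 2 to compound 4 in this assay, as each gives only a limit of the assay and not a number: the limit of > 200000 nM in this assay, at which 2 of the 4 values shown sit. The compounds shown leave open whether hydrogen in place of 4-methoxyphenyl changes the read-out at all, and what the true values of compound 2 and compound 4 are.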